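This account rests on a few compounds, and the source may have more. Where it says the series, first, only, none or still open, it means among the compounds named here.

Series notes. Compound 1 `Cc1cc(C(=O)NCN2CCC(c3cccc[n+]3[O-])CC2)ccc1F`, compound 2 `O=C(NCN1CCC(c2cccc[n+]2[O-])CC1)c1ccc(F)c(Cl)c1` and compound 3 `Cc1cc(C(=O)NCN2CCC(c3cccc[n+]3[O-])CC2)ccc1Cl` share one core and have been measured; compound 4 `Cc1ccc(C(=O)NCN2CCC(c3cccc[n+]3[O-])CC2)cc1C` has not. In a functional assay on HEK293 cells for agonist activity at D(4) dopamine receptor (Homo sapiens), read by FLIPR (on this read-out lower numbers stand for smaller maximal responses and higher numbers for larger maximal responses), compound 1 gives 67%, compound 2 gives 67% and compound 3 gives 62%. The step of no change at the digits printed from compound 2 to compound 1 (within the scatter) belongs to methyl in place of chloro on an aromatic carbon; the steps of a number 5 percentage points lower from compound 1 to compound 3 (within the scatter) and a number 5 percentage points lower from compound 2 to compound 3 (within the scatter) are of like size. The cores of compound 2 and compound 3 differ by 4-chloro-3-methylphenyl in place of 3-chloro-4-fluorophenyl on a carbonyl carbon. The change to compound 4 is methyl in place of chloro on an aromatic carbon, the same kind of change as that from compound 2 to compound 1, but its place is ortho to a methyl group and para to a large group, whereas the earlier place is ortho to a fluoro group and meta to a large group. Because no change at the digits printed from compound 2 to compound 1 (within the scatter) showed no change, the step of a number 1 percentage points higher from compound 3 to compound 4 (within the scatter) is expected to be small. Compound 4 is estimated at 63%, between 50% and 76%.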

Compound 4, largest response reached (reported as efficacy), in percent of the reference or control that the assay uses: 65%
Compound 4: the middle estimate sits 2 percentage points below what was measured; low and high end bracket the measured number.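

In this assay, methyl in place of chloro on an aromatic carbon gives a number 3 percentage points higher from compound 3 to compound 4 (within the scatter), and set beside the earlier case, the change reads alike on both cores: the same change on two cores in this assay, no change at the digits printed (within the scatter) from compound 2 to compound 1 and a number 3 percentage points higher (within the scatter) from compound 3 to compound 4, 3 percentage points apart, within the scatter of two such steps

The steps of a number 2 percentage points lower from compound 2 to compound 4 (within the scatter) and a number 2 percentage points lower from compound 1 to compound 4 (within the scatter) also stay inside the scatter. This supports carrying the change across these two cores only, at the two places tested and on this maximal response; it does not show that the change would stay silent on another core, at another place or in another read-out.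

All the aryl groups shown carry only methyl, fluoro or chloro. Going by these compounds, whether a nitrile, a methoxy group, an amine or a carboxylic acid on that ring would move the response beyond the scatter remains open.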